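This account rests on a few compounds, and the source may have more. Where it says the series, first, only, none or still open, it means among the compounds named here.

Measured in an assay on CHO cells for displacement of a labelled ligand from adenosine receptor A1 (Homo sapiens), read by scintillation counting, with a stated time of 60 min, tested at 10 uM; on this read-out higher numbers stand for more inhibition at the one concentration tested (going by the name of the read-out) and lower numbers for less inhibition:
compound 1 `CNC(=O)[C@@]12C[C@@H]1[C@@H](n1cnc3cnc(/C=C(\O)c4cnccn4)nc31)[C@H](O)[C@@H]2O`: 14%
compound 2 `CNC(=O)[C@@]12C[C@@H]1[C@@H](n1cnc3c(C)nc(C#Cc4ccccc4)nc31)[C@H](O)[C@@H]2O`: 15%
compound 3 `CNC(=O)[C@@]12C[C@@H]1[C@@H](n1cnc3c(/C=C(\O)c4ccccc4)nc(C#Cc4ccccc4)nc31)[C@H](O)[C@@H]2O`: 16%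

Compound 1 stands lowest of the three numbers, yet its gaps to compound 2 and to compound 3 lie within the scatter, so all three read as one level of inhibition. Going by the values given here, the only step between compounds differing in one place is a number 1 percentage points higher from compound 2 to compound 3 (within the scatter); it concerns another position and other groups and does not bear on the change at hand. Compound 4 `CNC(=O)[C@@]12C[C@@H]1[C@@H](n1cnc3cnc(NC)nc31)[C@H](O)[C@@H]2O` differs from compound 1 thus: methylamino in place of 2-hydroxy-2-(pyrazin-2-yl)ethenyl on an aromatic carbon. Among the compounds with values here, no measured step covers this exchange between two ring nitrogen atoms, so no step beyond the scatter is expected in this assay. Compound 4 is estimated at 14%, with a range from 2% to 30%. The step this estimate implies is no change at the digits printed from compound 1 to compound 4 (within the scatter).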

Compound 4, a percentage reported as inhibition, at one concentration (the size of the read-out at that concentration, not a potency): 17%
For compound 4 the middle estimate is 3 percentage points below the measured one, and the stated range covers the measured number.
By their numbers in this assay, from the lowest: compounds 1, 2, 3 and 4 (each within the scatter of the next).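

The exchange in this assay gives a number 3 percentage points higher from compound 1 to compound 4 (within the scatter) and so extends the earlier picture to this position: on this aromatic carbon between two ring nitrogen atoms, the read-out does not separate 2-hydroxy-2-(pyrazin-2-yl)ethenyl, with its 9 heavy atoms and aromatic ring, from methylamino, with 2 heavy atoms and no ring. No supporting data bear on why these two groups read alike. On these data alone, whether any group on this carbon moves the number beyond the scatter stays open, for example a carboxylic acid or a longer chain such as hexylamino.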